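The source may report more compounds than this note shows. Statements on the series, on what has been measured and on what is new or still open speak of the compounds shown alone.

Measured in a functional assay on HCT-116 cells (Homo sapiens) for inhibition, read by CCK-8 assay, with a stated time of 48 h; on this read-out lower numbers stand for stronger inhibition and higher numbers for weaker inhibition:
compound 1 `COc1ccc(-c2cc3nccc(-c4cc(OC)c(OC)c(OC)c4)n3n2)cc1N` gives 251 nM
compound 2 `COc1cc(-c2ccnc3cc(-c4ccc(Cl)cc4)nn23)cc(OC)c1OC` gives 3340 nM
compound 3 `COc1cc(-c2ccnc3cc(-c4ccc(N(C)C)cc4)nn23)cc(OC)c1OC` gives 2050 nM

Compound 3 stands second highest of these three numbers. Its nearest neighbour is compound 2, separated by a 1.6-fold lower number from compound 2 to compound 3 (0.21 log units; within the scatter); its furthest is compound 1, separated by an 8.2-fold higher number from compound 1 to compound 3 (0.91 log units; beyond the scatter).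

Compound 4 `COc1cc(-c2ccnc3cc(-c4cn(C)c5ccccc45)nn23)cc(OC)c1OC` is the next step from compound 3: 1-methyl-1H-indol-3-yl in place of 4-(dimethylamino)phenyl on an aromatic carbon. Among the compounds with values here, no measured step exchanges this pair of groups. The steps that do touch the same position are mixed: a 13-fold higher number from compound 1 to compound 2 (1.12 log units; beyond the scatter) and an 8.2-fold higher number from compound 1 to compound 3 (0.91 log units; beyond the scatter) show that swapping the group there can move the number well beyond the scatter, whereas a 1.6-fold lower number from compound 2 to compound 3 (0.21 log units; within the scatter) stayed within it. Compound 4 is therefore expected to shift modestly toward a lower number, a 1.7-fold lower number from compound 3 to compound 4 (0.23 log units; within the scatter). Compound 4 is estimated at 1200 nM, in a range from 300 nM to 5000 nM.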

Compound 4, half-maximal inhibitory concentration: 762 nM
For compound 4 the middle estimate is 1.6-fold (0.20 log units) above the measured one; low and high end bracket the measured number.
By their numbers in this assay, from the lowest: compound 1; then compound 4; then compounds 3 and 2 (each within the scatter of the next).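

In this assay, the position separates 1-methyl-1H-indol-3-yl from the two substituted phenyl groups that lay within the scatter of each other, with a 2.7-fold lower number from compound 3 to compound 4 (0.43 log units; beyond the scatter) and a 4.4-fold lower number from compound 2 to compound 4 (0.64 log units; beyond the scatter). The indole does not match 3-amino-4-methoxyphenyl, however, with a 3.0-fold higher number from compound 1 to compound 4 (0.48 log units; beyond the scatter), so this new group takes an intermediate place in the series. Nothing given here accounts for these differences. On these data alone, whether an indole without the methyl group, or an indole carrying an amine, would bring the number closer to that of compound 1 remains open.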